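The source may report more compounds than this note shows. Statements on the series, on what has been measured and on what is new or still open speak of the compounds shown alone.

Measured so far:
compound 1 `C(=C/c1nn2c(-c3ccncc3)nnc2s1)\c1ccco1` — 67%
compound 2 `COc1ccccc1-c1nnc2sc(/C=C/c3ccco3)nn12` — 75%

In an assay for inhibition of histone-lysine N-methyltransferase, H3 lysine-79 specific (Homo sapiens), read by scintillation counting, with stated times of 15 min and 60 min, tested at 50 uM, in the presence of a further agent that is not named here (on this read-out lower numbers stand for a weaker effect and higher numbers for a stronger effect at the one concentration tested), compound 1 gives 67%, the lowest of the two numbers at hand; its nearest neighbour is compound 2, whose 75% lies within the usual scatter of the read-out, so the two values cannot be told apart. Compound 3 `Fc1ccc(-c2nnc3sc(/C=C/c4ccco4)nn23)cc1` is not yet measured. It differs from compound 1 in one place: 4-fluorophenyl in place of pyridin-4-yl on an aromatic carbon. Going by the values given here, no step between measured compounds bears on this exchange, since compound 2 varies a different group. Among the compounds with values here, the only guidance is that both measured values fall close together. The account therefore expects no step beyond the scatter for this change, in either direction. Compound 3 is expected to give about 70% in this assay, with a range from 50% to 88%. The estimated step of a number 3 percentage points higher from compound 1 to compound 3 (within the scatter) is expected to stay within the scatter.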

Compound 3, a percentage reported as inhibition, at one concentration (the size of the read-out at that concentration, not a potency): 44%
Beside the measured number, compound 3's estimate is 26 percentage points above it; the whole stated range lies above it.
By their numbers in this assay, from the lowest: compound 3; then compounds 1 and 2 (each within the scatter of the next).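

In this assay, the exchange of pyridin-4-yl for 4-fluorophenyl on the aromatic carbon between two ring nitrogen atoms gives a number 23 percentage points lower from compound 1 to compound 3 (beyond the scatter), which shows that this position is not indifferent to the group it carries. The two earlier values lay within the scatter of each other and gave no sign of such a step. The change swaps a ring with one hetero atom and one hydrogen-bond acceptor for a carbon-only ring bearing fluorine, but no measurement here accounts for the step.

The compounds shown leave open whether the loss of the ring nitrogen or the arrival of the fluorine matters more, and a plain phenyl group would separate the two. They also leave open how an amine or a carboxylic acid on that ring would read at this position.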